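Replacing cyclohexyl with acetyl in compound 3

This account rests on a few compounds, and the source may have more. Where it says the series, first, only, none or still open, it means among the compounds named here.

Going by the values given here, in a functional assay (trachea) with Cavia porcellus as the target (on this read-out lower numbers stand for stronger inhibition and higher numbers for weaker inhibition), compound 3 `O=c1c2ccccc2c(-c2cccnc2)nn1CC1CCCCC1` gives 209 nM, the lowest number of the three measured so far. Compound 2 `O=c1c2ccccc2c(-c2cccnc2)nn1C1CCCC1` gives 2750 nM, and compound 1 `CCCCCCCCn1nc(-c2cccnc2)c2ccccc2c1=O` gives 21900 nM.

The next structure, compound 4 `CC(=O)Cn1nc(-c2cccnc2)c2ccccc2c1=O`, keeps the shared core and alters one group: acetyl in place of cyclohexyl on a saturated chain carbon bound to an aromatic nitrogen.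

Among the compounds with values here, two measured steps bear most directly on this change, a 13-fold lower number from compound 2 to compound 3 (1.12 log units; beyond the scatter) and a 100-fold lower number from compound 1 to compound 3 (2.02 log units; beyond the scatter). Both are large and show that this read-out responds strongly to the group on the aromatic nitrogen. Each of the other groups tested so far sits at a higher number than cyclohexylmethyl. None of them contains a carbonyl, however, so the size of the next step is uncertain. The expected change is a 12-fold higher number from compound 3 to compound 4 (1.08 log units; beyond the scatter), a large move towards a higher number. Compound 4 is estimated at about 2500 nM, with an expected range from 400 nM to 15000 nM.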

Compound 4, half-maximal inhibitory concentration: 40700 nM
Compound 4: the middle estimate sits 16-fold (1.21 log units) below what was measured; the whole stated range lies below it.
By their numbers in this assay, from the lowest: compound 3; then compound 2; then compounds 1 and 4 (each within the scatter of the next).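

In this assay, swapping cyclohexyl for acetyl on the saturated chain carbon gives a very large loss (a 190-fold higher number from compound 3 to compound 4 (2.29 log units; beyond the scatter)), so the low number of compound 3 does not survive this change. Compound 4 also stands well apart from the cyclopentyl compound (a 15-fold higher number from compound 2 to compound 4 (1.17 log units; beyond the scatter)), yet it cannot be told apart from the octyl compound (a 1.9-fold higher number from compound 1 to compound 4 (0.27 log units; within the scatter)). A short 2-oxopropyl group and a long octyl chain thus give matching results, so very different groups can share a high number here, while only cyclohexylmethyl reaches the lowest one.

The compounds shown do not separate losing the ring from gaining the carbonyl, which a plain propyl chain or a cyclohexyl ring carrying a carbonyl would help to do. How an amine or a carboxylic acid would fare at this position also remains open, and no measurement here explains the loss.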